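Compound 3 Meets a 3-Bromophenyl Group

The source may report more compounds than this note shows. Statements on the series, on what has been measured and on what is new or still open speak of the compounds shown alone.

In a functional assay on MCF7 cells (Homo sapiens) for antiproliferative activity, read by MTT assay, with a stated time of 72 h (on this read-out higher numbers stand for weaker inhibition and lower numbers for stronger inhibition), compound 1 `COc1cc(/C=C/c2ccc(C3=C(c4ccc(O)cc4)C4CC(S(=O)(=O)Oc5ccccc5)C3O4)cc2)cc(OC)c1` gives only a limit of the assay, > 100000 nM.

Compound 2 `CCc1ccccc1OS(=O)(=O)C1CC2OC1C(c1ccc(/C=C/c3cc(OC)cc(OC)c3)cc1)=C2c1ccc(O)cc1` gives 49800 nM and compound 3 `Cc1ccccc1OS(=O)(=O)C1CC2OC1C(c1ccc(/C=C/c3cc(O)cc(O)c3)cc1)=C2c1ccc(O)cc1` gives 55800 nM, two values that lie within the usual scatter of each other. Compound 3 therefore stands level with compound 2.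

Compound 4 `O=S(=O)(Oc1cccc(Br)c1)C1CC2OC1C(c1ccc(/C=C/c3cc(O)cc(O)c3)cc1)=C2c1ccc(O)cc1` differs from compound 3 in one place: 3-bromophenyl in place of 2-methylphenyl on an oxygen. In plain terms, 3-bromophenyl takes the place of 2-methylphenyl on an oxygen whose other neighbour is the sulfonyl sulfur.

Among the measured compounds shown here, only one measured step touches this group: an at least 2.0-fold lower number from compound 1 to compound 2 (0.30 log units; that floor lies within the scatter). For the measured compounds named here, it came from ethyl in place of hydrogen on an aromatic carbon, it starts from a limit, and no measured compound here carries bromine. It therefore offers only weak guidance, and it points to no clear direction for the new change.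

No shift beyond the scatter is expected in this assay, and the estimated step is a 1.4-fold lower number from compound 3 to compound 4 (0.14 log units; within the scatter).

For compound 4 the estimated value is 40000 nM, with an expected range from 12000 nM to 100000 nM.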

Compound 4, half-maximal inhibitory concentration: 19800 nM
Compound 4: the middle estimate sits 2.0-fold (0.31 log units) above what was measured; measured number inside the range.
By their numbers in this assay, from the lowest: compound 4; then compounds 2 and 3 (each within the scatter of the next). At a limit, above all of these: compound 1.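

In this assay, among the compounds shown here, this is the first step at the group on the oxygen whose other neighbour is the sulfonyl sulfur that runs between two real numbers and lies beyond the scatter: a 2.8-fold lower number from compound 3 to compound 4 (0.45 log units; beyond the scatter). The aryl group at this position can therefore shift the read-out modestly, even though 2-methylphenyl and 3-bromophenyl count the same heavy atoms and each has one six-membered aromatic ring. Nothing given here explains the shift.

As far as these compounds go, the change swaps methyl for bromine and alters the group's numbered position in one step, so it remains open which of the two matters; a 3-methylphenyl or 2-bromophenyl group on the same oxygen would separate them. From the compounds shown here alone, how an amine or a carboxylic acid on this ring would read in this assay also remains open.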